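Methylsulfonyl for methylsulfanyl on the shared core

The source may report more compounds than this note shows. Statements on the series, on what has been measured and on what is new or still open speak of the compounds shown alone.

Measured compounds:
compound 1, `CSc1cccc2c(=O)c(-c3nn[nH]n3)c[nH]c12`, giving 25 mg/kg in a functional assay on the whole organism (strain Sprague-Dawley) for inhibition, with Rattus norvegicus as the target; a lower number here means that less compound is needed, a higher number that more compound is needed for the effect
compound 2, `CCOc1cccc2cc(C(=O)O)cnc12`, giving only a limit, > 50 mg/kg, in this assay

For the measured compounds named here, compound 1 carries the only numbered result in this assay so far, with the minimum effective dose above. Compound 2 returns no number at all, only (the limit of > 50 mg/kg in this assay, at which 1 of the 2 values shown sits); nothing more can be read from it. Going by the values given here, no pair of measured compounds differs in a single place, so no measured step exists to lean on.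

Among the compounds with values here, compound 3, `CS(=O)(=O)c1cccc2c(=O)c(-c3nn[nH]n3)c[nH]c12`, is the one unmeasured member. It differs from compound 1 in one change: methylsulfonyl in place of methylsulfanyl on an aromatic carbon. The methylsulfanyl group leaves and the methylsulfonyl group enters, on an aromatic carbon of a six-membered aromatic ring of carbon only, part of a fused system of two rings.

Within the data shown here, with no comparable step measured, the change is expected to stay within the usual scatter in this assay, in either direction, and the estimate therefore rests on compound 1 alone. Compound 3 is expected near 25 mg/kg, between 8 mg/kg and 80 mg/kg. This estimate means an expected step of no change at the digits printed from compound 1 to compound 3 (within the scatter).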

Compound 3, minimum effective dose: > 25 mg/kg
Compound 3: no number, only a limit; the forecaster's own chance of this, stated with the estimate: 30%; the middle value lies on the limit itself.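

For the compounds shown here, this is the first measured step at this aromatic carbon of the shared core: in this assay, methylsulfonyl in place of methylsulfanyl gives a number no lower from compound 1 to compound 3 (the limit leaves the size open). Compound 3 therefore shows no sign that the added oxygens lower the dose needed, so the change offers no gain over the methylsulfanyl group of compound 1 within the dose range read here. The result for compound 3 is a limit and not a number, so it cannot place the step inside or beyond the usual scatter, and the size of the step cannot be read: the limit of > 25 mg/kg in this assay, at which 1 of the 3 values shown sits.

Still open, on these data alone, is whether compound 3 would respond at a dose close to the number for compound 1 or would need far more, and so whether this change matters at all or merely fails to help. Also open, as far as these compounds go, is what other groups on the same aromatic carbon would give, such as an amine or a longer chain like ethylsulfanyl, since the two groups compared here provide no trend that could be extended to them.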